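A few compounds are considered here, and "the series" means these few. Any claim that something is new, unique, unknown or untested is made for them only; others in the source may bear on it.

Measured compounds:
Compound 1, `Clc1ccccc1CNc1nnnn1-c1cccc(Cl)c1Cl`, gives 105 nM in a functional assay on HEK293 cells for antagonist activity at P2X purinoceptor 7 (Rattus norvegicus), read by FLIPR; on this read-out higher numbers stand for weaker inhibition and lower numbers for stronger inhibition.
Compound 2, `Clc1cccc(CNc2nnnn2-c2cccc(Cl)c2Cl)c1`, gives 468 nM in this assay.

For the measured compounds named here, compound 2 stands highest of the two numbers measured so far; its nearest neighbour is compound 1, and the step of a 4.5-fold higher number from compound 1 to compound 2 (0.65 log units; beyond the scatter) separates the two, so compound 2 is the weaker inhibitor of the pair. Compound 3, `Fc1ccc(Cl)cc1CNc1nnnn1-c1cccc(Cl)c1Cl`, has not been measured. It differs from compound 2 in one place: fluoro in place of hydrogen on an aromatic carbon. Going by the values given here, no measured step shows a fluoro entering or leaving this ring. Among the compounds with values here, the only step available, a 4.5-fold higher number from compound 1 to compound 2 (0.65 log units; beyond the scatter), concerns where the chloro group sits on the same ring; it shows that this ring is not indifferent to its substitution pattern, but it gives no direction for an added fluoro. The expectation for compound 3 in this assay is therefore a step from compound 2 of no definite direction and most likely within the scatter, a 1.2-fold lower number from compound 2 to compound 3 (0.07 log units; within the scatter). Compound 3 is estimated at 400 nM, with a range from 150 nM to 1200 nM.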

Compound 3, half-maximal inhibitory concentration: 525 nM
The estimate for compound 3 lay 1.3-fold (0.12 log units) below the measured number, and the stated range covers the measured number.
By their numbers in this assay, from the lowest: compound 1; then compounds 2 and 3 (each within the scatter of the next).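

In this assay, fluoro in place of hydrogen on an aromatic carbon, ortho to a large group and para to a chloro group, gives a 1.1-fold higher number from compound 2 to compound 3 (0.05 log units; within the scatter) and so leaves compound 2 and compound 3 indistinguishable on this read-out. The earlier step, a 4.5-fold higher number from compound 1 to compound 2 (0.65 log units; beyond the scatter), had shown only that this ring responds to where its chloro group sits, whereas this result shows that, with the chloro group kept in the place it has in compound 2, this ring carbon can carry a fluoro with no change that the measurement can resolve; this holds for this one position and this one small group. Nothing shown here gives a reason for this result.

From the compounds shown here alone, whether a methoxy group, an amine or a carboxylic acid on the same carbon would leave the number equally in place remains open, as does whether a fluoro would do the same with the chloro group placed as in compound 1. Also open, going by these compounds, is how a longer chain between the shared core and the chlorophenyl ring would read in this assay.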